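A few compounds are considered here, and "the series" means these few. Any claim that something is new, unique, unknown or untested is made for them only; others in the source may bear on it.

Measured so far:
compound 1 `O=C(N[C@@H]1CCNC1)c1cc(-c2ccc(NS(=O)(=O)c3cccc(Cl)c3Cl)cc2)nc2[nH]ncc12` gives < 1 nM in an assay for inhibition of serine/threonine-protein kinase Sgk1 (Homo sapiens), with stated times of 30 min and 60 min, in the presence of a further agent that is not named here; a higher number here means a weaker inhibitor, a lower number a stronger inhibitor
compound 2 `Cc1n[nH]c2nc(-c3ccc(NS(=O)(=O)c4cc(Cl)ccc4F)cc3)nc(OCCC(=O)N(C)C)c12` gives 438 nM in this assay

The value for compound 1 is a limit of this assay, not a number (the limit of < 1 nM in this assay, at which 1 of the 2 values shown sits). Compound 2 thus holds the only full number shown in this assay. Compound 3 `Cc1n[nH]c2nc(-c3ccc(NS(=O)(=O)c4cc(Cl)ccc4F)cc3)nc(OC3CCC(=O)CC3)c12` differs from compound 2 by 4-oxocyclohexyl in place of 2-(dimethylcarbamoyl)ethyl on an oxygen on an aromatic ring. For the measured compounds named here, no measured pair carries this change, so the step from compound 2 to compound 3 is expected to be a 1.1-fold lower number from compound 2 to compound 3 (0.04 log units; within the scatter), none beyond the scatter. Compound 3 in this assay is estimated at 400 nM, within 120 nM to 1300 nM.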

Compound 3, half-maximal inhibitory concentration: 18 nM
The estimate for compound 3 lay 22-fold (1.35 log units) above the measured number, outside the stated range (below it).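

In this assay, the group on this oxygen on an aromatic ring matters strongly for the shared core: 4-oxocyclohexyl in place of 2-(dimethylcarbamoyl)ethyl gives a 24-fold lower number from compound 2 to compound 3 (1.39 log units; beyond the scatter). The two groups have the same counts of heavy atoms, hydrogen-bond donors and acceptors, so those counts do not track the step; the groups differ in the six-membered carbon ring and the loss of the amide nitrogen. Nothing measured here explains the step. From the compounds shown here alone, whether the ring or its carbonyl carries the step remains open. A plain cyclohexyl, a 4-hydroxycyclohexyl or a piperidin-4-yl on this oxygen would separate the two.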